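Cyclohexyl in place of isobutyl on the amine-bearing carbon

This account rests on a few compounds, and the source may have more. Where it says the series, first, only, none or still open, it means among the compounds named here.

Compound 2 `COc1cccc(-c2c(C)n(Cc3c(F)cccc3F)c(=O)n(C[C@H](N)CC(C)C)c2=O)c1F` was measured in an ADME assay on the whole organism for metabolic stability, with Mus musculus as the target (on this read-out higher numbers stand for a longer-lived compound and lower numbers for a shorter-lived compound), where compound 2 gives 0.7 h. Going by the values given here, the only other measured compound, compound 1 `COc1cccc(-c2c(C)n(Cc3c(F)cccc3F)c(=O)n(C[C@H](C)NCc3ccccc3)c2=O)c1F`, gives 1.1 h in this assay; the one step between them, a 1.6-fold lower number from compound 1 to compound 2 (0.20 log units; within the scatter), replaces the whole side chain on the carbon bound to the aromatic nitrogen and stays within the scatter. Compound 3 `COc1cccc(-c2c(C)n(Cc3c(F)cccc3F)c(=O)n(C[C@H](N)C3CCCCC3)c2=O)c1F` differs from compound 2 in a smaller way: cyclohexyl in place of isobutyl on a saturated chain carbon bound to an amine nitrogen and a saturated chain carbon. Among the compounds with values here, no measured step touches this carbon, so the step from compound 1 to compound 2 bears on it only loosely, as a sign that a larger change in this region gave no movement beyond the scatter. Compound 3 is therefore expected to sit close to compound 2, with no change at the digits printed from compound 2 to compound 3 (within the scatter) amounting to no step beyond the scatter. The estimate for compound 3 in this assay is 0.7 h, in the range 0.35 h to 1.4 h.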

Compound 3, half-life: 1.3 h
For compound 3 the middle estimate is 1.9-fold (0.27 log units) below the measured one; the range from low to high includes it.
By their numbers in this assay, from the lowest: compounds 2, 1 and 3 (each within the scatter of the next).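

In this assay the change to cyclohexyl in place of isobutyl on the saturated chain carbon bound to an amine nitrogen gives a 1.9-fold higher number from compound 2 to compound 3 (0.27 log units; within the scatter), so this position now has a direct reading, and a six-membered non-aromatic ring of carbon only gives no step beyond the scatter there. The whole side chain can also be set against that of compound 1, with a 1.2-fold higher number from compound 1 to compound 3 (0.07 log units; within the scatter), which leaves all three compounds within the scatter of one another. Nothing shown gives a reason for these numbers.

From the compounds shown here alone, whether a phenyl ring or a methyl group on this carbon would move the half-life beyond the scatter stays open. So does whether the cyclohexyl compound would hold its number with a benzyl group on the amine nitrogen.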